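The compounds below may be only part of what the source reports. "The series", "measured", "known", "first", "only" and "open" are said of these compounds alone.

Measured compounds. In an assay on HEK293 cells for binding affinity to Urotensin-2 receptor (Homo sapiens), read by radioligand binding (a lower number here means a stronger inhibitor, a higher number a weaker inhibitor), compound 1 `Cc1cc(C(=O)N[C@H]2CCN(Cc3ccc(OCCCN(C)C)cc3)C2)ccc1Cl` gives 631 nM. Compound 3 `CC(C)C[C@H](NC(=O)c1ccc(Br)cc1)C(=O)N[C@H]1CCN(Cc2ccc(OCCCN(C)C)cc2)C1` gives 200 nM in this assay. Compound 2 `CN(C)CCCOc1ccc(CN2CC[C@H](NC(=O)c3ccc(C(F)(F)F)cc3)C2)cc1` reaches only a limit of the assay, < 10000 nM.

Compound 3 holds the lowest of the two numbers in this assay; compound 1 stands beyond the scatter above it, and compound 2 contributes only a limit (the limit of < 10000 nM in this assay, at which 1 of the 3 values shown sits). The step that the limit leaves unreadable from compound 1 to compound 2 is unreadable at that limit and gives no size. Compound 4 `CC(=O)N[C@@H](CC(C)C)C(=O)N[C@H]1CCN(Cc2ccc(OCCCN(C)C)cc2)C1` differs from compound 3 by methyl in place of 4-bromophenyl on a carbonyl carbon. Among the compounds with values here, no measured step exchanges the group on this carbonyl carbon in a readable way, so nothing here fixes the size of the step. Removing the 4-bromophenyl is expected to weaken binding, and compound 4 is estimated at 2500 nM (range 500 nM to 10000 nM), an expected step of a 13-fold higher number from compound 3 to compound 4 (1.10 log units; beyond the scatter).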

Compound 4, inhibition constant: 2510 nM
Compound 4: middle estimate off by 1.0-fold (0.00 log units), on the low side; the range from low to high includes it.
By their numbers in this assay, from the lowest: compound 3; then compound 1; then compound 4.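

Methyl in place of 4-bromophenyl on this carbonyl carbon gives the first readable step at this position, a 13-fold higher number from compound 3 to compound 4 (1.10 log units; beyond the scatter). With 1-acetamido-3-methylbutyl in place of 4-chloro-3-methylphenyl on the same carbon, the number also rises, a 4.0-fold higher number from compound 1 to compound 4 (0.60 log units; beyond the scatter), so this longer group with its acetamido end does not match the simple aryl amide of compound 1. Compound 2 stands at a limit, and its steps cannot be read: the limit of < 10000 nM in this assay, at which 1 of the 4 values shown sits.

From the compounds shown here alone, whether the bromine or the aromatic ring carries the step from 4-bromophenyl to methyl remains open. An unsubstituted phenyl or a cyclohexyl on this carbonyl carbon would separate the two.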